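Flexible ether chain in place of a cyclopropyl group

The source may report more compounds than this note shows. Statements on the series, on what has been measured and on what is new or still open speak of the compounds shown alone.

Compound 2 `Nc1ccc2cccc(OCC3CC3)c2n1` carries a cyclopropyl group on a saturated chain carbon bound to an oxygen on an aromatic ring. In an assay on cells with melanin-concentrating hormone receptor 1 (Homo sapiens) as the target, read by radioligand binding (a lower number here means a stronger inhibitor, a higher number a weaker inhibitor), compound 2 gives > 2000 nM, which is a limit of the assay and not a number. For the measured compounds named here, its only neighbour, compound 1 `CC#CCCOc1cccc2ccc(N)nc12`, differs by a but-2-yn-1-yl group in that place. In this assay compound 1 gives > 2000 nM, again a limit. The step that the two limits leave unreadable from compound 1 to compound 2 is therefore unreadable, and the evidence amounts to the limit of > 2000 nM in this assay, at which 2 of the 2 values shown sit.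

Compound 3 `COCCOCCOc1cccc2ccc(N)nc12` is the next variation: (2-methoxyethoxy)methyl in place of cyclopropyl on a saturated chain carbon bound to an oxygen on an aromatic ring. Going by the values given here, no measured step reads on this change, so the expectation rests only on both known compounds sitting at the limit. Compound 3 is expected to give 3000 nM, with a range from 500 nM to 20000 nM. The estimated step from compound 2 to compound 3 is a step that the limit leaves unreadable from compound 2 to compound 3.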

Compound 3, half-maximal inhibitory concentration: > 2000 nM
Compound 3 gave a limit, no number (the forecaster's own chance of this, stated with the estimate: 80%); the middle value is on the limit's open side.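

In this assay compound 3 gives > 2000 nM, which is a limit of the assay and not a number. Its steps from compound 1 and compound 2 therefore cannot be read. The compounds shown leave open which group in this place, if any, would give a measurable value: the limit of > 2000 nM in this assay, at which 3 of the 3 values shown sit.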